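Extending the Ester of Compound 3

The compounds below may be only part of what the source reports. "The series", "measured", "known", "first", "only" and "open" are said of these compounds alone.

Three compounds were tested in a functional assay on HCT-116 cells (Homo sapiens) for inhibition, read by MTT assay, with a stated time of 2 days, tested at 10 uM; on this read-out lower numbers stand for less inhibition and higher numbers for more inhibition at the one concentration tested (going by the name of the read-out). Compound 1 `COc1ccc(OC)c(-c2cn(-c3ccc(O)c(C(=O)OCCCc4ccccc4)c3)nn2)c1` gives 13%. Compound 2 `COC(=O)c1cc(-n2cc(-c3cccc(O)c3)nn2)ccc1O` gives 6%. Compound 3 `COC(=O)c1cc(-n2cc(-c3cc(O)ccc3O)nn2)ccc1O` gives 15%, the highest of the three numbers shown, although the step of a number 9 percentage points higher from compound 2 to compound 3 (within the scatter) lies within the scatter and the gap to compound 1 does too. Compound 4 `O=C(OCCCc1ccccc1)c1cc(-n2cc(-c3cc(O)ccc3O)nn2)ccc1O` differs from compound 3 by phenethyl in place of hydrogen on a saturated chain carbon bound to an oxygen next to a carbonyl group. Going by the values given here, no measured step covers this change directly; compound 1 already carries the longer ester, and its number sits close to that of compound 3. The expected step is therefore small, no change at the digits printed from compound 3 to compound 4 (within the scatter), with no direction beyond the scatter. Compound 4 is estimated to give 15%, in a range from 3% to 27%.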

Compound 4, a percentage reported as inhibition, at one concentration (the size of the read-out at that concentration, not a potency): 39%
Estimate against measurement, compound 4: 24 percentage points below; the whole stated range lies below it.
By their numbers in this assay, from the lowest: compounds 2, 1 and 3 (each within the scatter of the next); then compound 4.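

Replacing the methyl of the ester with 3-phenylpropyl gives a number 24 percentage points higher from compound 3 to compound 4 (beyond the scatter), so this position can change the read-out beyond the scatter when the 2,5-dihydroxyphenyl group is present. With the 3-phenylpropyl ester held constant, 2,5-dihydroxyphenyl in place of 2,5-dimethoxyphenyl gives a number 26 percentage points higher from compound 1 to compound 4 (beyond the scatter), so the longer ester does not produce this rise alone. No available evidence explains either step.

Going by these compounds, it remains open whether an ethyl ester or a longer chain would match compound 4. A carboxylic acid or an amide at this position is also an open case.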